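Exchanging one methyltetrazole for its isomer

The source may report more compounds than this note shows. Statements on the series, on what has been measured and on what is new or still open speak of the compounds shown alone.

In a functional assay for inhibition, with Homo sapiens as the target (a higher number here means a weaker inhibitor, a lower number a stronger inhibitor), compound 1 (`CC(=O)c1cc(-c2ccccc2)c2ccc(OCc3cccc(C4(O)CCOCC4)c3)cc2c1`) gives 2 nM and compound 2 (`Cn1nnc(-c2cc(-c3ccccc3)c3ccc(OCc4cccc(C5(O)CCOCC5)c4)cc3c2)n1`) gives 4 nM as its half-maximal inhibitory concentration, which lies within the scatter of compound 1. Compound 3 (`Cn1nnnc1-c1cc(-c2ccccc2)c2ccc(OCc3cccc(C4(O)CCOCC4)c3)cc2c1`) carries 1-methyl-1H-tetrazol-5-yl in place of 2-methyl-2H-tetrazol-5-yl on an aromatic carbon. Within the data shown here, the one measured step bearing on this, with 2-methyl-2H-tetrazol-5-yl replacing acetyl (a 2.0-fold higher number from compound 1 to compound 2 (0.30 log units; within the scatter)), stayed within the scatter. Among the measured compounds shown here, no measured step exchanges the two tetrazoles themselves, so only a small change is expected (a 1.5-fold higher number from compound 2 to compound 3 (0.18 log units; within the scatter)), none beyond the scatter. Compound 3 is estimated at 6 nM (range 2 nM to 20 nM).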

Compound 3, half-maximal inhibitory concentration: > 67 nM
Compound 3 gave a limit, no number; the forecaster's own chance of this, stated with the estimate: 3%; at least 11-fold (1.04 log units) between middle value and limit.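

Compound 3 gave only a limit in this assay, not a number: the limit of > 67 nM in this assay, at which 1 of the 3 values shown sits. At this position the two methyltetrazoles are not interchangeable, despite having the same atoms and the same counts of donors and acceptors: the exchange gives a large step (an at least 16-fold higher number from compound 2 to compound 3 (1.22 log units; beyond the scatter)). Measured against acetyl, 1-methyl-1H-tetrazol-5-yl also gives a large step (an at least 33-fold higher number from compound 1 to compound 3 (1.52 log units; beyond the scatter)), whereas 2-methyl-2H-tetrazol-5-yl stayed within the scatter.

The compounds shown do not tell why the two isomers part so sharply. They also leave open how an amine or a carboxylic acid would fare at this position.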